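The compounds below may be only part of what the source reports. "The series", "measured", "known", "first", "only" and "open" are said of these compounds alone.

Measured compounds in a physicochemical assay for lipophilicity, in phosphate buffer, measured as octanol-water partition, with a stated time of 24 h; a lower number here means a more polar compound, a higher number a more lipophilic compound:

- compound 1, `S=C(N/N=C/c1ccc(Oc2ccc3ccccc3c2)cc1)Nc1ccc(Cl)cc1`, gives 6.96
- compound 2, `S=C(N/N=C/c1ccc(Oc2ccc3ccccc3c2)cc1)Nc1ccccc1`, gives 6.07
- compound 3, `Fc1ccc(NC(=S)N/N=C/c2ccc(Oc3ccc4ccccc4c3)cc2)cc1`, gives 6.2

Compound 1 stands highest of the three numbers in this assay. Its nearest neighbour is compound 3, as the step of a number 0.76 log units lower from compound 1 to compound 3 (beyond the scatter) shows, and the step of a number 0.89 log units lower from compound 1 to compound 2 (beyond the scatter) is the largest measured. Between compound 2 and compound 3 the step of a number 0.13 log units higher from compound 2 to compound 3 (within the scatter) stays within the scatter. All three measured steps concern the aromatic carbon of the thiourea aryl ring, where chloro, fluoro or hydrogen sits.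

Compound 4, `Fc1ccc(Oc2ccc(/C=N/NC(=S)Nc3ccc(Cl)cc3)cc2)cc1`, has not yet been measured in this assay. It differs from compound 1 as follows: 4-fluorophenyl in place of naphthalen-2-yl on an oxygen on an aromatic ring. Among the measured compounds shown here, no measured pair changes the group on this oxygen, so none of the steps above bears directly on it; the only guidance is the within-scatter step a number 0.13 log units higher from compound 2 to compound 3 (within the scatter) for fluoro in place of hydrogen elsewhere on the core. Since 4-fluorophenyl carries fewer heavy atoms and one fewer aromatic ring than naphthalen-2-yl, a lowering in this assay beyond the scatter is expected, and compound 4 is estimated at 5.85, between 5.3 and 6.4. That estimate means an expected step of a number 1.11 log units lower from compound 1 to compound 4 (beyond the scatter).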

Compound 4, partition coefficient: 5.84
Beside the measured number, compound 4's estimate is 0.01 log units above it; measured number inside the range.
By their numbers in this assay, from the lowest: compounds 4, 2 and 3 (each within the scatter of the next, the first and the last beyond it); then compound 1.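

In this assay, among the compounds shown here, the group on an oxygen on an aromatic ring proves to be a place where the number moves: the step of a number 1.12 log units lower from compound 1 to compound 4 (beyond the scatter) is the first reading at this place and is a large one. All earlier steps concerned the aromatic carbon carrying chloro, fluoro or hydrogen, so they gave no reading of this oxygen substituent, and the number is now seen to respond to changes at a second place on the shared core. The change replaces naphthalen-2-yl, with 10 heavy atoms and 2 six-membered aromatic rings, by 4-fluorophenyl, with 7 heavy atoms and one such ring, and no measurement at hand gives a reason for the step.

With a single pair at this place, the loss of the second ring and the entry of the fluorine cannot be told apart, and a plain phenyl group on this oxygen would separate the two. Also open, from the compounds shown here alone, are how a carboxylic acid or an amine on this ring, or a short alkyl chain on the oxygen in place of the ring, would read in this assay, and whether the steps among chloro, fluoro and hydrogen hold with 4-fluorophenyl in place.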